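The compounds below may be only part of what the source reports. "The series", "measured", "known", "first", "only" and "open" are said of these compounds alone.

Of the compounds shown here, two sharing one core have been measured in an ADME assay for permeability, using PAMPA; a lower number here means that the compound crosses the layer more slowly, a higher number that the compound crosses the layer faster. Compound 1 `O=C(Nc1ccc(F)cc1Cl)c1cc(Cl)ccc1O` gives 50.5 10^-6 cm/s, while compound 2 `O=C(Nc1ccc(F)cc1)c1cc(Cl)ccc1O` gives 391 10^-6 cm/s, the higher of the two numbers. The step between them is a 7.7-fold higher number from compound 1 to compound 2 (0.89 log units; beyond the scatter), with hydrogen in place of chloro on an aromatic carbon.

Compound 3 `O=C(Nc1ccc(Cl)cc1)c1cc(Cl)ccc1O` has not yet been measured in this assay. It differs from compound 2 by chloro in place of fluoro on an aromatic carbon, which is chloro in place of fluoro on an aromatic carbon.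

For the measured compounds named here, only that one measured step bears on this change, and it bears on it loosely, since it exchanges chloro for hydrogen and not for fluoro. Still, the compound carrying the extra chloro there, compound 1, sits lower at 50.5 10^-6 cm/s. A change in the same direction is therefore expected for compound 3, but clearly smaller than that modest step, and it may not exceed the scatter. The expected step is a 1.5-fold lower number from compound 2 to compound 3 (0.18 log units; within the scatter). Compound 3 is estimated at 260 10^-6 cm/s, with an expected range from 100 10^-6 cm/s to 600 10^-6 cm/s.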

Compound 3, apparent permeability: 297 10^-6 cm/s
For compound 3 the middle estimate is 1.1-fold (0.06 log units) below the measured one; measured number inside the range.
By their numbers in this assay, from the lowest: compound 1; then compounds 3 and 2 (each within the scatter of the next).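

In this assay, chloro in place of fluoro on an aromatic carbon, para to a large group, gives a 1.3-fold lower number from compound 2 to compound 3 (0.12 log units; within the scatter), so this read-out does not separate the two halogens at this position. The earlier compounds shown here showed only a 7.7-fold higher number from compound 1 to compound 2 (0.89 log units; beyond the scatter), a step beyond the scatter in which hydrogen replaces chloro at another place in the shared core, and they said nothing about this position. For the compounds shown here, the new pair therefore adds a first reading here, and it shows that exchanging one of these halogens for the other at this position need not bring a step of that size, although no measurement at hand accounts for this result.

The compounds shown carry only fluoro and chloro at this position, so it remains open how the number would respond to an amine, a methoxy group or a carboxylic acid there. Also open is whether the exchange of fluoro for chloro would stay within the scatter if the core kept the further chloro of compound 1, since no such pair appears among these compounds.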